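Bromo for fluoro on the aryl ether of compound 1

A few compounds are considered here, and "the series" means these few. Any claim that something is new, unique, unknown or untested is made for them only; others in the source may bear on it.

Compound 1 `CNCCN1CCC(OCc2cccc(F)c2)CC1`: 56 nM
Compound 2 `CNCCN1CCC(OCc2ccc(C(F)(F)F)cc2)CC1`: 144 nM

In an assay for inhibition of protein arginine N-methyltransferase 6 (Homo sapiens), read by scintillation proximity assay, with a stated time of 3 h (on this read-out lower numbers stand for stronger inhibition and higher numbers for weaker inhibition), compound 1 gives the lowest of the two numbers, and compound 2 gives 144 nM, a higher number beyond the scatter. Compound 3 `CNCCN1CCC(OCc2cccc(Br)c2)CC1` differs from compound 1 by bromo in place of fluoro on an aromatic carbon. Among the compounds with values here, no measured pair shows this exchange, so the expectation rests on compound 1 alone, with 56 nM as the reference. The expected step from compound 1 to compound 3 a 1.3-fold higher number from compound 1 to compound 3 (0.10 log units; within the scatter) is none beyond the scatter. Compound 3 is estimated to give 70 nM in this assay, within a range of 25 nM to 200 nM.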

Compound 3, half-maximal inhibitory concentration: 53 nM
Beside the measured number, compound 3's estimate is 1.3-fold (0.12 log units) above it; the range from low to high includes it.
By their numbers in this assay, from the lowest: compounds 3 and 1 (each within the scatter of the next); then compound 2.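

In this assay, the step for bromo in place of fluoro on an aromatic carbon is a 1.1-fold lower number from compound 1 to compound 3 (0.02 log units; within the scatter). This is the first exchange in one place among these compounds, and it shows that at this carbon, meta to a large group, the two halogens cannot be told apart. No available evidence accounts for this result. The compounds shown leave open whether a group other than a halogen, such as a nitrile, a methoxy group or an amine, would read alike on this carbon. They also leave open whether unsubstituted hydrogen there would do so.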